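The compounds below may be only part of what the source reports. "The series", "measured", "known", "first", "only" and "open" are said of these compounds alone.

Compound 2 `COc1cc(/C=C/C(=O)c2cccc(NC(=O)c3ccccc3)c2)ccc1O` holds the second highest of the three numbers measured in a functional assay on U-87MG ATCC cells (Homo sapiens) for inhibition (a lower number here means a stronger inhibitor, a higher number a weaker inhibitor), where compound 2 gives 8.82 ug/mL; compound 1 `COc1cc(/C=C/C(=O)c2cccc(NC(=O)C(C)C)c2)ccc1O` gives 8.31 ug/mL and compound 3 `COc1cc(/C=C/C(=O)c2cccc(NC(=O)c3cccs3)c2)ccc1O` gives 14.7 ug/mL, both within the scatter of the value for compound 2. Compound 4 `CCCC(=O)Nc1cccc(C(=O)/C=C/c2ccc(O)c(OC)c2)c1` differs from compound 2 by propyl in place of phenyl on a carbonyl carbon. The step that bears on this most directly is a 1.1-fold higher number from compound 1 to compound 2 (0.03 log units; within the scatter), which also set an alkyl group against phenyl on a carbonyl carbon; a 1.8-fold higher number from compound 1 to compound 3 (0.25 log units; within the scatter) and a 1.7-fold higher number from compound 2 to compound 3 (0.22 log units; within the scatter) likewise stayed within the scatter. The chemist therefore expects no step beyond the scatter in this assay, a 1.0-fold lower number from compound 2 to compound 4 (0.02 log units; within the scatter), and estimates compound 4 at 8.5 ug/mL, within a range from 4.5 ug/mL to 16 ug/mL.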

Compound 4, half-maximal inhibitory concentration: 5.56 ug/mL
Estimate against measurement, compound 4: 1.5-fold (0.18 log units) above; low and high end bracket the measured number.
By their numbers in this assay, from the lowest: compounds 4, 1, 2 and 3 (each within the scatter of the next, the first and the last beyond it).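

In this assay, within the data shown here, propyl gives the one step at this position that passes the scatter, against thiophen-2-yl on a carbonyl carbon (a 2.6-fold lower number from compound 3 to compound 4 (0.42 log units; beyond the scatter)), and that step is modest. Propyl cannot be told apart from phenyl (a 1.6-fold lower number from compound 2 to compound 4 (0.20 log units; within the scatter)) or from isopropyl (a 1.5-fold lower number from compound 1 to compound 4 (0.17 log units; within the scatter)), so an open chain and a benzene ring read alike here. No measurement at hand explains the gap to thiophen-2-yl. The compounds shown leave open whether a longer chain, such as hexyl, or a group carrying an amine on this carbonyl carbon would separate from propyl.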